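The source may report more compounds than this note shows. Statements on the series, on what has been measured and on what is new or still open speak of the compounds shown alone.

Measured compounds:
compound 1, `NS(=O)(=O)NCC1CCN(c2cc(-c3ccc(C(F)(F)F)cc3)ncn2)CC1`, 43100 nM
compound 2, `NS(=O)(=O)NCC1CCN(c2cc(-c3cccc4ccccc34)ncn2)CC1`, 6600 nM
compound 3, `NS(=O)(=O)NCCC1CCN(c2cc(-c3ccc(C(F)(F)F)cc3)ncn2)CC1`, 34800 nM

These three compounds were tested in a functional assay on M21 cells (Homo sapiens) for antiproliferative activity, read by sulforhodamine B assay, with a stated time of 48 h; on this read-out lower numbers stand for stronger inhibition of growth and higher numbers for weaker inhibition of growth. Compound 1 and compound 3 share one core and differ in one place: (sulfamoylamino)methyl in place of sulfamoylamino on a saturated chain carbon bound to a saturated ring carbon. That change gave a 1.2-fold lower number from compound 1 to compound 3 (0.09 log units; within the scatter), so the two numbers are not told apart. Compound 2 carries a different core; the difference between the two cores is not broken down here. In this assay compound 2 gives the lowest number of the three, and its gap to compound 1 and to compound 3 lies beyond the scatter.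

Compound 4, `NS(=O)(=O)NCCC1CCN(c2cc(-c3cccc4ccccc34)ncn2)CC1`, has not been measured. It differs from compound 2 by (sulfamoylamino)methyl in place of sulfamoylamino on a saturated chain carbon bound to a saturated ring carbon, the same change that turns compound 1 into compound 3, at the same place. Since that change gave a 1.2-fold lower number from compound 1 to compound 3 (0.09 log units; within the scatter), the step is expected to be small here as well: a 1.1-fold lower number from compound 2 to compound 4 (0.04 log units; within the scatter). Compound 4 is therefore estimated at 6000 nM, with a range from 3000 nM to 12000 nM.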

Compound 4, concentration for 50% growth inhibition: 1800 nM
The estimate for compound 4 lay 3.3-fold (0.52 log units) above the measured number, and the stated range ends above it.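

In this assay the longer chain, 2-(sulfamoylamino)ethyl in place of (sulfamoylamino)methyl, gave a 3.7-fold lower number from compound 2 to compound 4 (0.56 log units; beyond the scatter) on the core of compound 2. The same change therefore did not carry over with the same size from one core to the other: the same change on two cores in this assay, a 1.2-fold lower number (0.09 log units; within the scatter) from compound 1 to compound 3 and a 3.7-fold lower number (0.56 log units; beyond the scatter) from compound 2 to compound 4, 3.0-fold (0.47 log units) apart, beyond the scatter of two such steps. Among the compounds shown here, with only one pair on each core, this shows that the size of the step can depend on the core, but not what in the two cores makes the difference or how the change would behave on a third core.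

The compounds shown leave open whether a still longer chain would lower the number further on either core, and whether an amine or a carboxylic acid at the end of the chain could stand in for the sulfamoyl group. From the compounds shown here alone, it also remains open whether a core with chlorine or a methoxy group in place of trifluoromethyl would follow the small step or the larger one.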